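This account rests on a few compounds, and the source may have more. Where it says the series, first, only, none or still open, it means among the compounds named here.

Compound 1 `CCCCNC(=O)COc1ccc(C(=O)c2c(CCCC)oc3ccccc23)cc1`: 22800 nM
Compound 2 `CCCCc1oc2ccccc2c1C(=O)c1ccc(OCC(=O)N2CCOCC2)cc1`: 45400 nM
Compound 3 `CCCCc1oc2ccccc2c1C(=O)c1ccc(OCC(=O)N2CCN(C(=O)OC(C)(C)C)CC2)cc1`: 23700 nM

All three values come from a functional assay on U-937 cells (Homo sapiens) for antiproliferative activity, read by MTT assay, with a stated time of 24 h; on this read-out lower numbers stand for stronger inhibition and higher numbers for weaker inhibition. Compound 2, at 45400 nM, has the highest number of the three, but it lies within the scatter of both compound 1 and compound 3, so the series shows no real separation so far.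

The next compound, compound 4 `CCCCc1oc2ccccc2c1C(=O)c1ccc(OCCCC(=O)N2CCCC2)cc1`, differs from compound 2 as follows: 2-((pyrrolidin-1-yl)carbonyl)ethyl in place of (morpholin-4-yl)carbonyl on a saturated chain carbon bound to an oxygen on an aromatic ring. In words, 2-((pyrrolidin-1-yl)carbonyl)ethyl stands in place of (morpholin-4-yl)carbonyl on a saturated chain carbon bound to an oxygen on an aromatic ring. Cut one bond further out, ((morpholin-4-yl)carbonyl)methyl gives way to 3-((pyrrolidin-1-yl)carbonyl)propyl.

Going by the values given here, only one measured step bears on this change. Exchanging the group on the carbonyl gave a 2.0-fold higher number from compound 1 to compound 2 (0.30 log units; within the scatter), which does not exceed the scatter. Among the compounds with values here, no measured compound varies the chain or carries the pyrrolidine, so that part of the change remains untested. On this evidence, no step beyond the scatter is expected in this assay. The expected step is a 1.5-fold lower number from compound 2 to compound 4 (0.18 log units; within the scatter). Compound 4 is estimated at 30000 nM, with an expected range from 12000 nM to 70000 nM.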

Compound 4, half-maximal inhibitory concentration: 7500 nM
Compound 4: the middle estimate sits 4.0-fold (0.60 log units) above what was measured; the whole stated range lies above it.
By their numbers in this assay, from the lowest: compound 4; then compounds 1, 3 and 2 (each within the scatter of the next).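

In this assay, the change on a saturated chain carbon bound to an oxygen on an aromatic ring gives a 6.1-fold lower number from compound 2 to compound 4 (0.78 log units; beyond the scatter), and the same position, measured against the butylcarbamoyl group, gives a 3.0-fold lower number from compound 1 to compound 4 (0.48 log units; beyond the scatter), so this position can carry a step beyond the scatter. The earlier exchanges of the group on the carbonyl, with the chain left as it was, had kept compound 1, compound 2 and compound 3 within the scatter of one another, whereas compound 4 differs from compound 1 and compound 2 in both the chain and the ring on the carbonyl and stands clear of both. The chain and the ring change together in these steps, the numbers do not divide either step between them, and no evidence at hand accounts for them.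

As far as these compounds go, it remains open whether the pyrrolidin-1-yl group on the shorter chain of compound 2, or the morpholin-4-yl group on the longer chain of compound 4, would produce a comparable step. Also open, from the compounds shown here alone, is how a piperidin-1-yl amide, a still longer chain or a carboxylic acid in place of the amide would read at this position.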